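Amide substituent variation on the shared core

A few compounds are considered here, and "the series" means these few. Any claim that something is new, unique, unknown or untested is made for them only; others in the source may bear on it.

The series varies the group on an amide-type nitrogen of a shared core. Compound 1 `O=C(COc1ccc2cc(/C=C3/SC(=O)NC3=O)ccc2c1)Nc1cccc(F)n1` gives 7200 nM in an assay on isolated protein for inhibition of histone deacetylase 8 (Homo sapiens), with a stated time of 1 h; a higher number here means a weaker inhibitor, a lower number a stronger inhibitor. Going by the values given here, compound 2 `O=C(COc1ccc2cc(/C=C3/SC(=O)NC3=O)ccc2c1)Nc1ccc(F)cc1` gives 6600 nM in this assay; this is the lower of the two numbers so far, with compound 1 as the nearest point, but the step of a 1.1-fold lower number from compound 1 to compound 2 (0.04 log units; within the scatter) lies within the scatter, so no order between the two can be read. Compound 3 `Cc1cccc2sc(NC(=O)COc3ccc4cc(/C=C5/SC(=O)NC5=O)ccc4c3)nc12` is not yet measured. The change from compound 2 is 4-methyl-1,3-benzothiazol-2-yl in place of 4-fluorophenyl on an amide-type nitrogen. Among the compounds with values here, only one measured step exists, a 1.1-fold lower number from compound 1 to compound 2 (0.04 log units; within the scatter), and it exchanges one six-membered aromatic ring of carbon only for another on an amide-type nitrogen; it does not cover the entry of a group holding a five-membered aromatic ring with two hetero atoms, so no measured step bears directly on this change. The step to compound 3 is therefore expected to be small, a 1.3-fold lower number from compound 2 to compound 3 (0.12 log units; within the scatter), with no direction that the data support beyond the scatter. Compound 3 is estimated at 5000 nM, within 1500 nM to 16000 nM.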

Compound 3, half-maximal inhibitory concentration: 5800 nM
Beside the measured number, compound 3's estimate is 1.2-fold (0.06 log units) below it; the range from low to high includes it.
By their numbers in this assay, from the lowest: compounds 3, 2 and 1 (each within the scatter of the next).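

In this assay, this place on an amide-type nitrogen now takes 4-methyl-1,3-benzothiazol-2-yl, with 10 heavy atoms, one five-membered aromatic ring with 2 hetero atoms and 2 hydrogen-bond acceptors, in place of 4-fluorophenyl, with 7 heavy atoms, a single six-membered aromatic ring of carbon only and 0 hydrogen-bond acceptors, and the result is a 1.1-fold lower number from compound 2 to compound 3 (0.06 log units; within the scatter). Set against 6-fluoropyridin-2-yl, the same group gives a 1.2-fold lower number from compound 1 to compound 3 (0.09 log units; within the scatter), so all three numbers lie within the scatter of one another, and this larger two-ring group separates itself from neither single-ring group in this read-out. No data given here bear on what lies behind these numbers.

All three groups shown place an aromatic ring directly on the amide-type nitrogen, so it remains open whether a saturated ring such as cyclohexyl, a longer alkyl chain, or a chain ending in an amine or a carboxylic acid would give a number beyond the scatter of these three. Going by these compounds, it also remains open whether any group at this place can move the number far from these values while the shared core stays as it is.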